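This account rests on a few compounds, and the source may have more. Where it says the series, first, only, none or still open, it means among the compounds named here.

In a functional assay on SK-LU-1 cells (Homo sapiens) for inhibition, read by sulforhodamine B assay, with a stated time of 48 h, tested at 50 uM (on this read-out higher numbers stand for more inhibition of growth at the one concentration tested and lower numbers for less inhibition of growth), compound 1 `O=C(Nc1cn2cc(I)ccc2n1)C(F)(F)F` gives 25.6% and compound 2 `O=C(c1ccc(C(F)(F)F)c(F)c1)c1ccc2nc(NC(=O)C(F)(F)F)cn2c1` gives 48.3%, the higher of the two numbers, with a gap beyond the usual scatter. Compound 3 `Cc1ccc(C(=O)c2ccc3nc(NC(=O)C(F)(F)F)cn3c2)cc1F` carries methyl in place of trifluoromethyl on an aromatic carbon, ortho to a fluoro group and para to a large group (methyl in place of trifluoromethyl on an aromatic carbon). Among the measured compounds shown here, no measured pair shows this change, so the expectation is weakly grounded. The expected step is a number 6.3 percentage points lower from compound 2 to compound 3 (within the scatter), a small fall within the scatter. In this assay the estimate for compound 3 is 42%, with an expected range of 25% to 58%.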

Compound 3, percent growth inhibition at one concentration: 81.5%
Compound 3: the middle estimate sits 39.5 percentage points below what was measured, and the stated range ends below it.
By their numbers in this assay, from the lowest: compound 1; then compound 2; then compound 3.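

Methyl in place of trifluoromethyl on an aromatic carbon, ortho to a fluoro group and para to a large group, gives a number 33.2 percentage points higher from compound 2 to compound 3 (beyond the scatter) in this assay and is the only single-place comparison in the series. Growth inhibition at this position therefore depends strongly on the group it carries, which compound 1 could not show. Nothing shown here accounts for the step.

Among the compounds shown here, only two groups are compared at this position, so the trend remains undefined. From the compounds shown here alone, it remains open how an ethyl group, a methoxy group or an amine would behave there, and whether the step holds without the fluoro group.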